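The source may hold more compounds than are shown below. What is called first, only, known or untested is meant among the compounds shown, and "the series" means these compounds.

Compound 2 `N#C/C(=C\N1CCN(C(=O)c2ccco2)C1=S)C(N)=O`, with 22100 nM in a functional assay on SW-620 cells (Homo sapiens) for inhibition, read by sulforhodamine B assay, with a stated time of 48 h; a higher number here means a weaker inhibitor of growth, a lower number a stronger inhibitor of growth; compound 1 `N#C/C(=C\N1CCN(C(=O)c2ccco2)C1=S)C(=O)Nc1ccc(Cl)cc1`, with 17300 nM.

On these two numbers compound 2 has the higher one, but its distance to compound 1, a 1.3-fold higher number from compound 1 to compound 2 (0.11 log units; within the scatter), lies within the scatter, so the two cannot be ordered. Compound 3 `N#C/C(=C\N1CCN(C(=O)c2ccco2)C1=S)C(=O)c1ccccc1` differs from compound 2 in one place: phenyl in place of amino on a carbonyl carbon. Among the compounds with values here, no measured step matches this change. Within the data shown here, the only step that bears on it is the one from compound 1 to compound 2, a 1.3-fold higher number from compound 1 to compound 2 (0.11 log units; within the scatter), which exchanged a 4-chlorophenyl for hydrogen at the amide-type nitrogen of the same carbonyl without moving the number beyond the scatter. By that analogy, a change at this carbonyl is expected to give no step beyond the scatter in this assay, with at most a slight drift to a lower number, so the step from compound 2 to compound 3 is estimated at a 1.2-fold lower number from compound 2 to compound 3 (0.09 log units; within the scatter). Compound 3 is therefore expected to give about 18000 nM in this assay, in a range from 7000 nM to 45000 nM.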

Compound 3, concentration for 50% growth inhibition: 5900 nM
Estimate against measurement, compound 3: 3.1-fold (0.48 log units) above, and the stated range ends above it.
By their numbers in this assay, from the lowest: compound 3; then compounds 1 and 2 (each within the scatter of the next).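

In this assay, the carbonyl carbon had shown no step beyond the scatter when only the group on the amide-type nitrogen changed, but it does respond when that nitrogen is replaced by phenyl. Phenyl in place of amino gives a modest step (a 3.7-fold lower number from compound 2 to compound 3 (0.57 log units; beyond the scatter)), and phenyl in place of (4-chlorophenyl)amino gives another in the same direction (a 2.9-fold lower number from compound 1 to compound 3 (0.47 log units; beyond the scatter)), so compound 3 stands apart from both amides. No measurement shown here explains this difference.

On these data alone, what stays open is whether the lower number depends on the phenyl ring itself or would also appear with a methyl on this carbonyl carbon. As far as these compounds go, it is equally open how a 4-chlorobenzoyl or a 4-methoxybenzoyl group would compare with the benzoyl of compound 3.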